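The compounds below may be only part of what the source reports. "The series", "measured", "known", "first", "only" and "open" are said of these compounds alone.

Measured in a functional assay on MCF7 cells (Homo sapiens) for inhibition; a lower number here means a stronger inhibitor, a higher number a weaker inhibitor:
Compound 1, `CC/C(=C(/c1ccc(/C=C/C(=O)O)cc1)c1cc2ccccc2[nH]1)c1cccc(OC(F)(F)F)c1`: 282 nM
Compound 2, `CC/C(=C(/c1ccc(/C=C/C(=O)O)cc1)c1cc2ccccc2[nH]1)c1ccc(C(F)(F)F)cc1`: 139 nM

Of these two, compound 2 gives the lower number, and the step of a 2.0-fold lower number from compound 1 to compound 2 (0.31 log units; beyond the scatter) lies beyond the scatter, so compound 2 stands as the stronger inhibitor of the pair. Compound 3, `CC/C(=C(/c1ccc(/C=C/C(=O)O)cc1)c1cc2ccccc2[nH]1)c1cccc(Cl)c1Cl`, keeps the shared core and alters only the aryl group on the chain: 2,3-dichlorophenyl in place of 4-(trifluoromethyl)phenyl on a double-bonded chain carbon bound to a double-bonded chain carbon and a saturated chain carbon. For the measured compounds named here, the single measured step, a 2.0-fold lower number from compound 1 to compound 2 (0.31 log units; beyond the scatter), compares two other aryl groups, each of which differs from 2,3-dichlorophenyl in the kind of halogen-bearing group it carries, so it offers only weak guidance for compound 3. Going by the values given here, it shows that exchanging this aryl group can shift the number modestly, but gives no direction for the new group, and no measured compound carries a chlorine-bearing aryl group. The expectation for compound 3 in this assay is therefore a step of a 1.4-fold higher number from compound 2 to compound 3 (0.16 log units; within the scatter), expected to stay within the usual scatter, with a value estimated at 200 nM and a range from 70 nM to 600 nM.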

Compound 3, half-maximal inhibitory concentration: 898 nM
Compound 3: the middle estimate sits 4.5-fold (0.65 log units) below what was measured; measured number above the stated range.
By their numbers in this assay, from the lowest: compound 2; then compound 1; then compound 3.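

In this assay, the aryl group on the double-bonded chain carbon turns out to matter more than the first pair suggested: a 6.5-fold higher number from compound 2 to compound 3 (0.81 log units; beyond the scatter) is a wider move than a 2.0-fold lower number from compound 1 to compound 2 (0.31 log units; beyond the scatter) seen before. The 2,3-dichlorophenyl group also loses ground against the other earlier group, with a 3.2-fold higher number from compound 1 to compound 3 (0.50 log units; beyond the scatter) also beyond the scatter, so compound 3 is the weakest inhibitor of the three and this position does not accept every halogen-bearing aryl group equally. No measurement available here explains why the two chlorines give the weakest result of the set.

The three aryl groups differ both in what they carry and in where their names place it, so these compounds cannot show whether the chlorines themselves or their arrangement on the ring drives the loss. From the compounds shown here alone, how a plain phenyl ring, or a phenyl ring carrying a single chlorine, a nitrile or an amine, would rank against compound 2 remains open.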